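The source may report more compounds than this note shows. Statements on the series, on what has been measured and on what is new or still open speak of the compounds shown alone.

Compound 1, `CC(C)(C)c1ccc(/C(=C/C(=O)Nc2ccc3c(c2)OCCO3)c2cccnc2)cc1`, gives 510 nM in a functional assay on CHO cells for inhibition of transient receptor potential cation channel subfamily V member 1 (Homo sapiens); a higher number here means a weaker inhibitor, a lower number a stronger inhibitor.
Compound 2, `CC(C)C/C(=C\C(=O)Nc1ccc2c(c1)OCCO2)c1ccc(C(C)(C)C)cc1`, gives 94 nM in this assay.
Compound 3, `CCOC(=O)CC/C(=C\C(=O)Nc1ccc2c(c1)OCCO2)c1ccc(C(C)(C)C)cc1`, gives 290 nM in this assay.

Compound 3 holds the second highest of the three numbers: it lies near compound 1, as shown by a 1.8-fold lower number from compound 1 to compound 3 (0.25 log units; within the scatter), while compound 2 sits clearly lower, as shown by a 3.1-fold higher number from compound 2 to compound 3 (0.49 log units; beyond the scatter). Compound 4, `CC(C)(C)c1ccc(/C(=C/C(=O)Nc2ccc3c(c2)OCCO3)CCC(=O)O)cc1`, differs from compound 3 by hydrogen in place of ethyl on an oxygen next to a carbonyl group. Both measured steps alter the same chain, yet neither removes the ethyl from this oxygen, so they give only loose guidance. The expectation is therefore a small step, probably upward in number but possibly within the scatter, namely a 2.1-fold higher number from compound 3 to compound 4 (0.32 log units; beyond the scatter). Compound 4 is estimated to give 600 nM, with a range from 150 nM to 2500 nM.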

Compound 4, half-maximal inhibitory concentration: > 4000 nM
Compound 4 was reported as a limit; the forecaster's own chance of this, stated with the estimate: 10%; middle value at least 6.6-fold (0.82 log units) away from the limit.
By their numbers in this assay, from the lowest: compound 2; then compounds 3 and 1 (each within the scatter of the next). At a limit, above all of these: compound 4.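

Compound 4 is reported only as a limit: the limit of > 4000 nM in this assay, at which 1 of the 4 values shown sits. Hydrogen in place of ethyl on an oxygen next to a carbonyl group turns ethoxycarbonyl into carboxy and gives an at least 13-fold higher number from compound 3 to compound 4 (1.13 log units; beyond the scatter), so this small change matters far more than the earlier chain changes suggested. Compound 4 also stands well apart from the other two, with an at least 42-fold higher number from compound 2 to compound 4 (1.62 log units; beyond the scatter) and an at least 7.8-fold higher number from compound 1 to compound 4 (0.89 log units; beyond the scatter).

On these data alone, it remains open whether an amide or an alcohol in place of the carboxy group would track compound 3 or compound 4. A methyl ester would test how much of the ethyl is needed.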